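A few compounds are considered here, and "the series" means these few. Any claim that something is new, unique, unknown or untested is made for them only; others in the source may bear on it.

In a functional assay on aorta (Rattus norvegicus, strain Wister) (a higher number here means a weaker inhibitor, a lower number a stronger inhibitor), compound 1 `COc1nc(-c2nc3ccccc3n2C)cc(-c2ccc(Cl)cc2Cl)c1C#N` gives 214000 nM, compound 2 `COc1nc(-c2nc3ccccc3n2C)cc(-c2ccc(F)cc2)c1C#N` gives 343000 nM, and compound 3 `CCOc1nc(-c2nc3ccccc3n2C)cc(-c2ccc(F)cc2)c1C#N` gives 362000 nM. Compound 2 thus holds the second highest of these three numbers, with both other compounds lying within the scatter of it. Compound 4 `COc1nc(-c2nc3ccccc3n2C)cc(-c2cccs2)c1C#N` differs from compound 2 by thiophen-2-yl in place of 4-fluorophenyl on an aromatic carbon. Among the measured compounds shown here, the one measured step that also exchanges the group on this same aromatic carbon is a 1.6-fold higher number from compound 1 to compound 2 (0.20 log units; within the scatter), while the other step, a 1.1-fold higher number from compound 2 to compound 3 (0.02 log units; within the scatter), alters a different place; neither shifted the number beyond the scatter. No shift beyond the scatter is therefore expected here either, and compound 4 is estimated at 350000 nM, with a range from 150000 nM to 800000 nM, which corresponds to the expected step of a 1.0-fold higher number from compound 2 to compound 4 (0.01 log units; within the scatter).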

Compound 4, half-maximal inhibitory concentration: 312000 nM
Beside the measured number, compound 4's estimate is 1.1-fold (0.05 log units) above it; measured number inside the range.
By their numbers in this assay, from the lowest: compounds 1, 4, 2 and 3 (each within the scatter of the next).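

At this aromatic carbon, a five-membered ring carrying sulfur is now tested in place of a six-membered carbon ring: this assay shows a 1.1-fold lower number from compound 2 to compound 4 (0.04 log units; within the scatter) and a 1.5-fold higher number from compound 1 to compound 4 (0.16 log units; within the scatter). Thiophen-2-yl, 4-fluorophenyl and 2,4-dichlorophenyl therefore all lie within the scatter of one another, despite differing in ring size and in hydrogen-bond acceptor count. Nothing available explains this lack of separation. As far as these compounds go, all three groups are aromatic rings, so it remains open whether an amine or a carboxylic acid at this carbon would move the number beyond the scatter.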